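Piperazine variation on the shared core: compound 4 estimate

This account rests on a few compounds, and the source may have more. Where it says the series, first, only, none or still open, it means among the compounds named here.

Measured compounds:
compound 1 `CCN1CCN(c2cccc3c2C[C@H](CN(C)[C@H]2CCCc4cccnc42)NC3)CC1` — 13.8 nM
compound 2 `CN(C[C@H]1Cc2c(cccc2N2CCN3CCC[C@@H]3C2)CN1)[C@H]1CCCc2cccnc21` — 3.59 nM
compound 3 `CN1CCN(c2cccc3c2C[C@H](CN(C)[C@H]2CCCc4cccnc42)NC3)CC1` — 29.6 nM

In a functional assay on CCRF-CEM cells for antagonist activity at C-X-C chemokine receptor type 4 (Homo sapiens), read by calcium flux, with stated times of 25 min and 90 s (on this read-out lower numbers stand for stronger inhibition and higher numbers for weaker inhibition), compound 3 stands at the highest number of the three, with compound 1 nearest and compound 2 furthest. The steps that reach it both run upward: a 2.1-fold higher number from compound 1 to compound 3 (0.33 log units; beyond the scatter) and an 8.2-fold higher number from compound 2 to compound 3 (0.92 log units; beyond the scatter).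

Compound 4 `CN(C[C@H]1Cc2c(cccc2N2CCNC(C)(C)C2)CN1)[C@H]1CCCc2cccnc21` is not yet measured. It differs from compound 3 at one place: 3,3-dimethylpiperazin-1-yl in place of 4-methylpiperazin-1-yl on an aromatic carbon. The ring amine that carried the methyl in compound 3 now carries hydrogen, while two methyl groups enter on a ring carbon.

Among the measured compounds shown here, two measured steps bear on this change. The loss of the methyl on the chain carbon bound to the ring amine gave a 2.1-fold higher number from compound 1 to compound 3 (0.33 log units; beyond the scatter). Replacing the bicyclic group with 4-methylpiperazin-1-yl gave an 8.2-fold higher number from compound 2 to compound 3 (0.92 log units; beyond the scatter). Both show that compound 3 sits at the weaker end of what changes on this ring have produced, and that adding carbon to the ring has so far gone with lower numbers. For the measured compounds named here, no measured compound carries a ring amine with hydrogen in place of methyl, so that part of the change is untested.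

A modest downward step, a 2.5-fold lower number from compound 3 to compound 4 (0.39 log units; beyond the scatter), is therefore expected. Compound 4 is estimated at 12 nM, with a range from 5 nM to 35 nM.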

Compound 4, half-maximal inhibitory concentration: 33.9 nM
For compound 4 the middle estimate is 2.8-fold (0.45 log units) below the measured one; the measured number falls inside the stated range.
By their numbers in this assay, from the lowest: compound 2; then compound 1; then compounds 3 and 4 (each within the scatter of the next).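

In this assay, 3,3-dimethylpiperazin-1-yl in place of 4-methylpiperazin-1-yl on this aromatic carbon gives a 1.1-fold higher number from compound 3 to compound 4 (0.06 log units; within the scatter), so the two groups cannot be told apart at this position, even though the ring amine carries hydrogen in one and methyl in the other. Extra carbon on the piperazine does not by itself go with a lower number here: compound 4 goes against the trend seen in the earlier compounds, and the 4-ethylpiperazin-1-yl group, with the same heavy-atom count as 3,3-dimethylpiperazin-1-yl, performs better, with a 2.5-fold higher number from compound 1 to compound 4 (0.39 log units; beyond the scatter) for the change to the dimethyl group. The fused bicyclic group of compound 2 keeps a clear margin over the new group, with a 9.4-fold higher number from compound 2 to compound 4 (0.98 log units; beyond the scatter), which makes the shape of the added carbon matter more than its amount within these compounds.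

No measurement on hand accounts for these steps. Still open, going by these compounds, is how the two parts of the change contribute separately, which an unsubstituted piperazin-1-yl, a 3,3-dimethyl-4-methylpiperazin-1-yl or a 4-propylpiperazin-1-yl group on the shared core would help to separate.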